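The source may report more compounds than this note shows. Statements on the series, on what has been measured and on what is new or still open speak of the compounds shown alone.

Within the data shown here, in a functional assay on MDA-MB-231 cells (Homo sapiens) for inhibition, read by MTT assay, with a stated time of 48 h (on this read-out lower numbers stand for stronger inhibition of growth and higher numbers for weaker inhibition of growth), compound 1 `CC(C)c1ccc(Nc2ncnc3ccc(NC(=S)NCc4ccccc4)cc23)cc1` gives 12800 nM as the only exact number so far. Compound 2 `O=S(=O)(Nc1nccs1)c1ccc(NC(=S)Nc2ccc3ncnc(Nc4cccc(Br)c4)c3c2)cc1` gives > 30000 nM which is a limit and not a number, so it stands at the limit of > 30000 nM in this assay, at which 1 of the 2 values shown sits, with no exact value. Compound 3 `S=C(Nc1ccc(Br)cc1)Nc1ccc2ncnc(Nc3cccc(Br)c3)c2c1` carries bromo in place of (1,3-thiazol-2-yl)sulfamoyl on an aromatic carbon, para to a large group, and the change counts as bromo in place of (1,3-thiazol-2-yl)sulfamoyl on an aromatic carbon in all. Among the measured compounds shown here, no measured step guides this change, so only a moderate move toward stronger inhibition of growth is expected. The estimated step of an at least 2.5-fold lower number from compound 2 to compound 3 (0.39 log units; beyond the scatter) is uncertain in size because compound 2 has only > 30000 nM as its starting point. Compound 3 is expected to give 12000 nM with a range from 4000 nM to 30000 nM as estimated here.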

Compound 3, concentration for 50% growth inhibition: > 30000 nM
Compound 3 gave a limit, no number (the forecaster's own chance of this, stated with the estimate: 20%); middle value at least 2.5-fold (0.39 log units) from the limit.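

No new step can be read from compound 2 to compound 3, because each gives a limit and not an exact number: the limit of > 30000 nM in this assay, at which 2 of the 3 values shown sit. Going by these compounds, whether bromo or (1,3-thiazol-2-yl)sulfamoyl gives stronger inhibition of growth in this assay stays open.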